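A Side-Group Swap on the Chain of Compound 1

A few compounds are considered here, and "the series" means these few. Any claim that something is new, unique, unknown or untested is made for them only; others in the source may bear on it.

Compound 1 `CC(C)c1ncc([C@@H](CCCCCCc2ccc3c(n2)NCCC3)CC(=O)O)cn1` gives "not determined" (no result reported) in an in vivo ADME assay on the whole organism (Canis lupus familiaris) for pharmacokinetics; on this read-out lower numbers stand for slow clearance and higher numbers for fast clearance: no number for it is known. Compound 2 `O=C(O)CC(NC(=O)CCCCc1ccc2c(n1)NCCC2)c1cncnc1`, which shares the same core, gives 26 mL/min/kg in this assay. Compound 3 `COc1ccc([C@@H](CCCCCCc2ccc3c(n2)NCCC3)CC(=O)O)cn1` differs from compound 1 by 6-methoxypyridin-3-yl in place of 2-isopropylpyrimidin-5-yl on a saturated chain carbon bound to two saturated chain carbons. Among the measured compounds shown here, no measured step joins these compounds. Neither the size nor the direction of the change can be read from the data; the expectation is a shift in this assay that stays within the usual scatter, in either direction, near where compound 2 lies. Compound 3 is therefore estimated at 18 mL/min/kg, expected to fall between 6 mL/min/kg and 45 mL/min/kg.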

Compound 3, clearance in the Canis lupus familiaris assay: 5.1 mL/min/kg
Estimate against measurement, compound 3: 3.5-fold (0.55 log units) above; measured number outside the range, below it.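

Among the compounds shown here, no step in the Canis lupus familiaris assay can be read from compound 1 to compound 3. In a physicochemical assay for lipophilicity (on this read-out lower numbers stand for lower lipophilicity and higher numbers for higher lipophilicity), compound 1 gives 1.32 and compound 3 gives 1.67. Going by these compounds, what 6-methoxypyridin-3-yl in place of 2-isopropylpyrimidin-5-yl does in the Canis lupus familiaris assay stays open.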